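The source may hold more compounds than are shown below. What is called first, only, known or untested is meant among the compounds shown, and "the series" means these compounds.

Measured compounds:
compound 1, `O=C(Nc1ccc(-n2ccc3c(NC(=O)c4ccccc4)nccc32)cc1)Nc1cccc(Cl)c1Cl`, > 10000 nM
compound 2, `O=C(Nc1ccc(-n2ccc3c(NC(=O)c4ccccc4)nccc32)cc1)c1ccc(Cl)c(C(F)(F)F)c1`, 16.4 nM

Two compounds share one core and differ only in the group attached to the carbonyl carbon on the outer ring. In a functional assay on A-375 cells (Homo sapiens) for antiproliferative activity, read by MTT assay, with a stated time of 48 h, in the presence of a further agent that is not named here (a higher number here means a weaker inhibitor, a lower number a stronger inhibitor), compound 2 gives 16.4 nM. For compound 1 the result is only a limit of the assay, > 10000 nM, which says the number lies outside what the assay reports (the limit of > 10000 nM in this assay, at which 1 of the 2 values shown sits). The step of an at least 600-fold lower number from compound 1 to compound 2 (2.78 log units; beyond the scatter) is the only one measured, and it concerns the amide end of the molecule, not the core. For the measured compounds named here, compound 2 therefore stands as the one compound with a number in this assay.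

Compound 3, `Nc1nccc2c1ccn2-c1ccc(NC(=O)c2ccc(Cl)c(C(F)(F)F)c2)cc1`, keeps the amide of compound 2 and changes the other end: hydrogen in place of benzoyl on a nitrogen on an aromatic ring. Going by the values given here, no measured step touches this nitrogen, so the step from compound 1 to compound 2 gives no direct guide to its size; the expectation rests on the new bare amino group alone. The estimated step is a 3.7-fold higher number from compound 2 to compound 3 (0.56 log units; beyond the scatter), a moderately weaker inhibitor than compound 2. Compound 3 is thus expected to give about 60 nM in this assay, within a range of 10 nM to 400 nM.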

Compound 3, half-maximal inhibitory concentration: 3800 nM
The estimate for compound 3 lay 63-fold (1.80 log units) below the measured number; measured number above the stated range.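

The step between compound 1 and compound 2 concerned only the amide end of the molecule, so it said nothing about the benzamido group at the other end, which both compounds share. In this assay, amino in place of benzamido gives a 230-fold higher number from compound 2 to compound 3 (2.36 log units; beyond the scatter), which shows that this end also has a large influence on the result and that the benzoyl on this nitrogen is tied to the low number of compound 2. Compound 3 still gives a number rather than a limit, so the size of this loss can be read directly: the limit of > 10000 nM in this assay, at which 1 of the 3 values shown sits.

The compounds shown carry only benzoyl or hydrogen on this nitrogen, so it remains open whether a small acetyl group or a plain methyl would hold on to part of the activity, or whether the whole benzoyl with its ring is needed. On these data alone, this step also rests on a single pair with one amide end, so it is unknown whether the same change would have a similar effect with another group at that end.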